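Urea nitrogen demethylation in the triazolopyridine sulfonamide series

The compounds below may be only part of what the source reports. "The series", "measured", "known", "first", "only" and "open" are said of these compounds alone.

Measured compounds:
- compound 1 `COc1ncc(-c2ccc3nc(NC(=O)NCCN4CCCC4)nn3c2)cc1NS(=O)(=O)c1ccc(F)cc1`: 1120 nM
- compound 2 `COc1ncc(-c2ccc3nc(NC(=O)N(C)C)nn3c2)cc1NS(=O)(=O)c1ccc(F)cc1`: 1780 nM
- compound 3 `CCN(CC)CCNC(=O)Nc1nc2ccc(-c3cnc(OC)c(NS(=O)(=O)c4ccc(C)cc4)c3)cn2n1`: 670 nM

All three were read in a functional assay on U-87MG ATCC cells for cytotoxicity against U-87 MG (Homo sapiens), read by MTT assay, with a stated time of 72 h; on this read-out lower numbers stand for stronger inhibition and higher numbers for weaker inhibition. Compound 2 carries the highest number of the three; the one-place step a 1.6-fold higher number from compound 1 to compound 2 (0.20 log units; within the scatter) lies within the scatter, while compound 3 sits beyond the scatter on the lower side.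

Compound 4 `CNC(=O)Nc1nc2ccc(-c3cnc(OC)c(NS(=O)(=O)c4ccc(F)cc4)c3)cn2n1` differs from compound 2 by hydrogen in place of methyl on an amide-type nitrogen. Within the data shown here, no measured pair shows this exact change. Among the measured compounds shown here, the only one-place step, from compound 1 to compound 2, exchanges a larger substituent on the carbonyl carbon for dimethylamino and gives a 1.6-fold higher number from compound 1 to compound 2 (0.20 log units; within the scatter), a movement that stays within the scatter. Compound 3, with a different chain on the urea, gives 670 nM, but it also carries another sulfonamide aryl group, so it cannot be read as a clean step. The urea substituent therefore appears to shift the read-out only modestly within this set, and a single methyl removed from the amide-type nitrogen is expected to move it little: the step of a 1.0-fold higher number from compound 2 to compound 4 (0.00 log units; within the scatter) is estimated to stay within the scatter. For compound 4 the expected value is 1800 nM, with a range of 800 nM to 4000 nM.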

Compound 4, half-maximal inhibitory concentration: 640 nM
Compound 4: the middle estimate sits 2.8-fold (0.45 log units) above what was measured; the whole stated range lies above it.
By their numbers in this assay, from the lowest: compounds 4, 3, 1 and 2 (each within the scatter of the next, the first and the last beyond it).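

In this assay, among these compounds, hydrogen in place of methyl on the amide-type nitrogen is the first one-place change in this set to move the number beyond the scatter (a 2.8-fold lower number from compound 2 to compound 4 (0.44 log units; beyond the scatter)). The loss of this one methyl therefore registers at this nitrogen, whereas hydrogen in place of (pyrrolidin-1-yl)methyl on the saturated chain carbon bound to that nitrogen stays within the scatter (a 1.8-fold lower number from compound 1 to compound 4 (0.24 log units; within the scatter)), so the size of the change does not track the size of the step across these fluorophenyl sulfonamide ureas. No measurement of any property bears on this result, and the numbers offer no explanation for it.

Going by these compounds, one pair cannot separate the effect of the hydrogen now on this nitrogen from that of the methyl lost from it, and it remains open whether an ethyl or cyclopropyl group on that nitrogen, or a morpholine at the end of the chain, would read with compound 4 or with compound 2. Compound 3 differs from these compounds in both its urea chain and its sulfonamide aryl group, so the contribution of each remains unresolved.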